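The source may report more compounds than this note shows. Statements on the series, on what has been measured and on what is new or still open speak of the compounds shown alone.

Working notes on the series. In a functional assay on HEL cells (Homo sapiens) for inhibition (a lower number here means a stronger inhibitor, a higher number a weaker inhibitor), compound 3 `CC(C)c1cc(-c2n[nH]c(=O)n2-c2cccc(C(=O)NCCCCC(=O)NO)c2)c(O)cc1O` gives 4600 nM, level with compound 1 `CC(C)c1cc(-c2n[nH]c(=O)n2-c2cccc(C(=O)NCCCCCC(=O)NO)c2)c(O)cc1O` at 4600 nM and compound 2 `CC(C)c1cc(-c2n[nH]c(=O)n2-c2cccc(C(=O)NCCCC(=O)NO)c2)c(O)cc1O` at 4600 nM.

The next structure is compound 4 `CNC(=O)CCCCCCCNC(=O)c1cccc(-n2c(-c3cc(C(C)C)c(O)cc3O)n[nH]c2=O)c1`. The difference is 3-(methylcarbamoyl)propyl in place of hydroxycarbamoyl on a saturated chain carbon, four bonds along the chain from an amide-type nitrogen: 3-(methylcarbamoyl)propyl in place of hydroxycarbamoyl, on a saturated chain carbon, four bonds along the chain from an amide-type nitrogen.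

Going by the values given here, three measured steps bear on this position: no change at the digits printed from compound 1 to compound 2 (within the scatter), no change at the digits printed from compound 1 to compound 3 (within the scatter) and no change at the digits printed from compound 2 to compound 3 (within the scatter). Each alters the chain while keeping the hydroxycarbamoyl at its end, and none of them moves beyond the scatter. They therefore show a flat response in this assay to the chain changes sampled so far. They say nothing direct about losing the hydroxycarbamoyl, since every measured compound carries it. The chain in compound 4 also runs beyond those sampled.

Among the compounds with values here, with no measured step pointing either way, no direction can be assigned, and the expectation stays anchored on compound 3 at 4600 nM. The expected step is no change at the digits printed from compound 3 to compound 4 (within the scatter), with none foreseen beyond the scatter. The range is kept wide to cover the unsampled change. For compound 4 the estimated value is 4600 nM, with an expected range of 1200 nM to 15000 nM.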

Compound 4, half-maximal inhibitory concentration: 4600 nM
Beside the measured number, compound 4's estimate shows no gap at the digits printed, within the range that was stated.
By their numbers in this assay, from the lowest: compounds 1, 2, 3 and 4 (each within the scatter of the next).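

Within this assay, exchanging hydroxycarbamoyl for 3-(methylcarbamoyl)propyl gives no change at the digits printed from compound 3 to compound 4 (within the scatter) and the comparisons with the other chain lengths read the same, with no change at the digits printed from compound 2 to compound 4 (within the scatter) and no change at the digits printed from compound 1 to compound 4 (within the scatter) as the two further steps. Compound 4 is the only compound shown without the hydroxycarbamoyl, so the series now shows that removing this group, together with extending the chain and ending it in methylcarbamoyl, leaves the read-out within the scatter, whereas the earlier steps varied only the chain and held the hydroxycarbamoyl in place. Nothing accompanies these values that could account for the flat response.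

Chain length and end group change together in compound 4, so a hydroxycarbamoyl on that longer chain would be needed to separate the two, and a methylcarbamoyl on the shorter chain of compound 3 would test the same point from the other side. From the compounds shown here alone, a carboxylic acid or a primary amine at the chain end also remains open, as does any change on the shared core, which stays the same throughout these compounds.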